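Swapping a cyclohexyl for a difluoromethoxy group

A few compounds are considered here, and "the series" means these few. Any claim that something is new, unique, unknown or untested is made for them only; others in the source may bear on it.

Measured so far:
compound 1, `O=C1NCCN1c1ccc(S(=O)(=O)Nc2ccc3[nH]ccc3c2)cc1`, 87 nM
compound 2, `O=C1NCCN1c1ccc(S(=O)(=O)Nc2ccc(C3CCCCC3)cc2)cc1`, > 1000 nM

Both were tested in a functional assay on M21 cells (Homo sapiens) for antiproliferative activity, read by sulforhodamine B assay, with a stated time of 48 h; a lower number here means a stronger inhibitor, a higher number a weaker inhibitor. Compound 1 gives 87 nM in this assay. Compound 2 reaches only the limit of this assay, > 1000 nM, so no number is known for it; it sits at the limit of > 1000 nM in this assay, at which 1 of the 2 values shown sits. The two values therefore cannot be set against each other as a measured step.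

Compound 3 is `O=C1NCCN1c1ccc(S(=O)(=O)Nc2ccc(OC(F)F)cc2)cc1`. It differs from compound 2 in one place: difluoromethoxy in place of cyclohexyl on an aromatic carbon. Among the measured compounds shown here, no step between measured compounds covers this kind of change, and compound 2 itself is only a limit, so the expectation rests on little. Compound 3 is expected to land near the same limit, at 800 nM with a range of 200 nM to 3000 nM. The step of an at least 1.2-fold lower number from compound 2 to compound 3 (0.09 log units; that floor lies within the scatter) is thus estimated as small, in the direction of a stronger inhibitor but not clearly beyond the scatter, and it remains quite possible that compound 3 is also reported only as a limit.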

Compound 3, half-maximal inhibitory concentration: 410 nM
Compound 3: the middle estimate sits 2.0-fold (0.29 log units) above what was measured; low and high end bracket the measured number.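

In this assay, replacing cyclohexyl with difluoromethoxy on this aromatic carbon brings an at least 2.4-fold lower number from compound 2 to compound 3 (0.38 log units; beyond the scatter), which shows that the group at this position can change the antiproliferative result by more than the usual scatter. Difluoromethoxy differs from cyclohexyl in several ways at once: it has fewer heavy atoms, no ring and a hydrogen-bond acceptor, so this single change cannot show which of these differences matters. The true size of the step remains unknown, and the printed figure is only a floor, because the value for compound 2 is a limit of the assay rather than a number: the limit of > 1000 nM in this assay, at which 1 of the 3 values shown sits.

Going by these compounds, it remains open whether methoxy, which keeps the oxygen without the fluorine atoms, or trifluoromethoxy, which adds a third fluorine, would give a lower or a higher number than compound 3. On these data alone, it is also open whether a butyl chain, which has only carbon like cyclohexyl but no ring, would stay at the limit seen for compound 2 or give a measurable value, and that comparison would help separate the loss of the ring from the arrival of oxygen and fluorine.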